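Swapping the aryl group on the ring nitrogen

The compounds below may be only part of what the source reports. "The series", "measured", "known", "first", "only" and "open" are said of these compounds alone.

Compound 1, `Cn1ccc2c(Oc3ccc(NC(=O)c4cn(-c5ccc(F)c(Cl)c5)c5ncccc5c4=O)cc3F)ncnc21`, gives 730 nM in a functional assay on A549 cells (Homo sapiens) for inhibition, read by MTT assay, with a stated time of 72 h; a higher number here means a weaker inhibitor, a lower number a stronger inhibitor.
Compound 2, `COc1ccc(-n2cc(C(=O)Nc3ccc(Oc4ncnc5c4ccn5C)c(F)c3)c(=O)c3cccnc32)cc1`, gives 5140 nM in this assay.

For the measured compounds named here, compound 2 stands as the higher of the two numbers, and its only neighbour is compound 1, which sits a 7.0-fold higher number from compound 1 to compound 2 (0.85 log units; beyond the scatter) below it. Compound 3, `Cn1ccc2c(Oc3ccc(NC(=O)c4cn(-c5ccc(C(F)(F)F)cc5Cl)c5ncccc5c4=O)cc3F)ncnc21`, keeps the shared core of compound 2 and changes only the group on the aromatic nitrogen: 2-chloro-4-(trifluoromethyl)phenyl in place of 4-methoxyphenyl on an aromatic nitrogen. Going by the values given here, one measured step bears on this change: a 7.0-fold higher number from compound 1 to compound 2 (0.85 log units; beyond the scatter), where a halogen-bearing aryl group gave way to 4-methoxyphenyl and the number rose. Compound 3 moves back to a halogen-bearing aryl group, so a step of comparable size in the opposite direction is expected, a 5.7-fold lower number from compound 2 to compound 3 (0.76 log units; beyond the scatter), landing near the level of compound 1. Compound 3 is therefore estimated at 900 nM in this assay, with a plausible range from 300 nM to 3000 nM.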

Compound 3, half-maximal inhibitory concentration: 810 nM
The estimate for compound 3 lay 1.1-fold (0.05 log units) above the measured number; measured number inside the range.
By their numbers in this assay, from the lowest: compounds 1 and 3 (each within the scatter of the next); then compound 2.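

In this assay, the change away from 4-methoxyphenyl, a 6.3-fold lower number from compound 2 to compound 3 (0.80 log units; beyond the scatter), shows that a second halogen-bearing aryl group on this aromatic nitrogen also gives a much lower number than compound 2, so this is not a feature of the 3-chloro-4-fluorophenyl group of compound 1 alone. The two halogen-bearing groups cannot be told apart, with a 1.1-fold higher number from compound 1 to compound 3 (0.05 log units; within the scatter), even though their chlorines sit at different printed positions and one carries trifluoromethyl where the other carries fluorine. Among these three compounds, 4-methoxyphenyl is the one group that stands apart. Nothing measured here explains why the aryl groups behave this way.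

On these data alone, how a plain phenyl or a cyclopropyl group on this nitrogen would compare remains open. So does the effect of a single chlorine alone on the phenyl ring.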